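The compounds below may be only part of what the source reports. "The series", "measured", "known", "first", "only" and "open" are said of these compounds alone.

Compound 1, `Cc1ccccc1-c1noc(-c2ccc(C3CCCCC3)cc2)n1`, was examined in a functional assay on CHO cells with sphingosine 1-phosphate receptor 2 (Homo sapiens) as the target, read by GTPgammaS binding; a lower number here means that less compound is needed, a higher number that more compound is needed for the effect. For compound 1 the assay reports only a limit, > 10000 nM, and no number. Two related compounds carry a carboxylic acid chain on the shared core. Compound 2, `CC[C@H](C)Oc1ccc(-c2nc(-c3ccc(CCC(=O)O)cc3C)no2)cc1C#N`, likewise stops at a limit in this assay, > 10000 nM. Compound 3, `Cc1cc(CCC(=O)O)ccc1-c1noc(-c2ccc(OC(C)C(F)(F)F)c(C#N)c2)n1`, again gives only a limit, > 10000 nM. For the measured compounds named here, the single one-place step among the measured compounds, a step that the two limits leave unreadable from compound 2 to compound 3, cannot be sized, since both of its ends sit at the limit of > 10000 nM in this assay, at which 3 of the 3 values shown sit. Compound 4, `Cc1cc(CCCCCC(=O)O)ccc1-c1noc(-c2ccc(C3CCCCC3)cc2)n1`, is compound 1 with 5-carboxypentyl in place of hydrogen on an aromatic carbon. Going by the values given here, no measured step bears directly on that change; the three limits show only that every compound tested so far, with or without an acid chain, fails to reach a readable effect in this assay. Against that background no step beyond the scatter is expected, and the change from compound 1 to compound 4 is written as a number no higher from compound 1 to compound 4 (the limit leaves the size open). Compound 4 is therefore estimated at 10000 nM, within 3000 nM to 30000 nM, and is most likely to be reported once more only as a limit.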

Compound 4, half-maximal effective concentration: > 10000 nM
Compound 4: only a limit was reported; the forecaster's own chance of this, stated with the estimate: 75%; the middle value sits exactly at the limit.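

Compound 1 and compound 4 both give only a limit in this assay, and no new step can be read between them. The compounds shown leave open how much 5-carboxypentyl in place of hydrogen changes the effect, and whether any compound on the shared core gives a readable number in this assay.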